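Replacing the triazole arm of compound 3

The source may report more compounds than this note shows. Statements on the series, on what has been measured and on what is new or still open speak of the compounds shown alone.

In a functional assay on MCF7 cells (Homo sapiens) for cytotoxicity, read by MTT assay, with a stated time of 72 h (on this read-out higher numbers stand for weaker inhibition and lower numbers for stronger inhibition), compound 3 `O=C1c2c[n+]([O-])c3ccccc3c2C(=O)c2c1c1ccccc1n2Cc1cn(CC(O)CO)nn1` gives 1110 nM, within the scatter of compound 1 `O=C1c2c[n+]([O-])c3ccccc3c2C(=O)c2c1c1ccccc1n2Cc1cn([C@H]2O[C@H](CO)[C@@H](O)[C@H]2O)nn1` at 1490 nM, while compound 2 `O=C1c2c[n+]([O-])c3ccccc3c2C(=O)c2c1c1ccccc1n2Cc1cn([C@@H]2C[C@H](O)[C@@H](CO)O2)nn1` stands clearly lower at 110 nM. Compound 4 `O=C1c2c[n+]([O-])c3ccccc3c2C(=O)c2c1c1ccccc1n2CCCCN1CCCCC1` differs from compound 3 by 3-(piperidin-1-yl)propyl in place of 1-(2,3-dihydroxypropyl)-1H-1,2,3-triazol-4-yl on a saturated chain carbon bound to an aromatic nitrogen. The measured steps all keep the triazole, so they offer only a rough scale: a 1.3-fold lower number from compound 1 to compound 3 (0.13 log units; within the scatter) stayed within the scatter, a 10-fold higher number from compound 2 to compound 3 (1.00 log units; beyond the scatter) was modest and a 14-fold lower number from compound 1 to compound 2 (1.13 log units; beyond the scatter) was large. A modest step is therefore expected in this assay, tentatively downward, as a 2.8-fold lower number from compound 3 to compound 4 (0.44 log units; beyond the scatter). Compound 4 is estimated at 400 nM, with an expected range of 80 nM to 1800 nM.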

Compound 4, half-maximal inhibitory concentration: 150 nM
Compound 4: the middle estimate sits 2.7-fold (0.43 log units) above what was measured; the measured number falls inside the stated range.
By their numbers in this assay, from the lowest: compounds 2 and 4 (each within the scatter of the next); then compounds 3 and 1 (each within the scatter of the next).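

The result shows that in this assay the triazole can leave this position without loss: 3-(piperidin-1-yl)propyl, with 0 hydrogen-bond donors, brings a clear step (a 7.4-fold lower number from compound 3 to compound 4 (0.87 log units; beyond the scatter)) on the saturated chain carbon bound to an aromatic nitrogen. A low number therefore no longer rests on the 4-hydroxy-5-(hydroxymethyl)oxolan-2-yl group alone, since compound 2 at 110 nM and compound 4 at 150 nM lie within the scatter of each other. Nothing available explains this step.

Open, as far as these compounds go, is whether a morpholine ring or a dimethylamino group in place of the piperidine ring, or a shorter or longer chain, would hold this level.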